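The source may report more compounds than this note shows. Statements on the series, on what has been measured and on what is new or still open speak of the compounds shown alone.

Of the compounds shown here, two have been measured in a physicochemical assay for solubility, read by nephelometry, in phosphate buffer, measured as kinetic solubility, at pH 6.5; a lower number here means a less soluble compound, a higher number a more soluble compound. Compound 1 `COc1ccc(-c2cc(-c3ccc(S(N)(=O)=O)cc3)cnc2N)cn1` gives 12.5 ug/mL in this assay and stands at the upper end of the two numbers, with compound 2 `COc1ccc(-c2cc(-c3ccc(S(C)(=O)=O)c(F)c3)cnc2N)cn1` giving 6.3 ug/mL, within the scatter of compound 1. Compound 3 `COc1ccc(-c2cc(-c3ccc(-n4cccn4)cc3)cnc2N)cn1` is not yet measured; it differs from compound 1 by 1H-pyrazol-1-yl in place of sulfamoyl on an aromatic carbon. Within the data shown here, no measured pair shows this change, so its size is unknown from the series. The step of a 3.1-fold lower number from compound 1 to compound 3 (0.49 log units; beyond the scatter) is expected to be a moderate decrease, somewhat beyond the scatter. For compound 3 the estimate is 4 ug/mL, with a range from 1.5 ug/mL to 12 ug/mL.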

Compound 3, solubility: 3.1 ug/mL
Beside the measured number, compound 3's estimate is 1.3-fold (0.11 log units) above it; the measured number falls inside the stated range.
By their numbers in this assay, from the lowest: compound 3; then compounds 2 and 1 (each within the scatter of the next).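

In this assay, 1H-pyrazol-1-yl in place of sulfamoyl on an aromatic carbon, para to a large group, gives a 4.0-fold lower number from compound 1 to compound 3 (0.61 log units; beyond the scatter) and so lies beyond the scatter. Among these compounds, this is the first single-place step, giving this position a measured size that compounds 1 and 2, which differ in more than one place, could not give. No measurement available here accounts for the size of this step.

On these data alone, whether an amine or a carboxylic acid at this position would stand above or below compound 1 remains open. Also open, as far as these compounds go, is whether this step holds on other members.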